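The compounds below may be only part of what the source reports. "The series", "measured", "known", "first", "only" and "open" are said of these compounds alone.

In an assay on CHO cells for displacement of a labelled ligand from adenosine receptor A3 (Homo sapiens), tested at 1 uM (on this read-out higher numbers stand for more inhibition at the one concentration tested (going by the name of the read-out) and lower numbers for less inhibition), compound 1 `CCOC(=O)Nc1ccc(C)cc1-n1cnc(-c2ccc(OC)cc2)n1` gives 34% and compound 2 `C#CCOC(=O)Nc1ccc(C)cc1-n1cnc(-c2ccc(OC)cc2)n1` gives 35%, so compound 2 holds the larger of the two numbers, with compound 1 lying within the scatter of it. Compound 3 `COc1ccc(-c2ncn(-c3cc(C)ccc3NC(=O)OCc3ccccc3)n2)cc1` differs from compound 2 by phenyl in place of ethynyl on a saturated chain carbon bound to an oxygen next to a carbonyl group. Among the measured compounds shown here, the one measured step that bears on this change, at the same saturated chain carbon, is a number 1 percentage points higher from compound 1 to compound 2 (within the scatter), within the scatter; on that basis the change is expected to give a number 1 percentage points higher from compound 2 to compound 3 (within the scatter) in this assay. Compound 3 is therefore estimated at 36%, spanning 20% to 52%.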

Compound 3, a percentage reported as inhibition, at one concentration (the size of the read-out at that concentration, not a potency): 47%
Compound 3: middle estimate off by 11 percentage points, on the low side; the measured number falls inside the stated range.
By their numbers in this assay, from the lowest: compounds 1 and 2 (each within the scatter of the next); then compound 3.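

Phenyl in place of ethynyl on the saturated chain carbon bound to an oxygen next to a carbonyl group gives a number 12 percentage points higher from compound 2 to compound 3 (beyond the scatter), and phenyl in place of methyl there gives a number 13 percentage points higher from compound 1 to compound 3 (beyond the scatter). This position therefore does respond to the group it carries, which the two earlier compounds alone did not show. Nothing measured here accounts for the rise with phenyl. The compounds shown leave open how a longer chain, a cyclohexyl ring or an amine would fare on this carbon.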